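Cytotoxicity on colon cells: three limits and one open question

The source may report more compounds than this note shows. Statements on the series, on what has been measured and on what is new or still open speak of the compounds shown alone.

Compound 1 `Cc1cccc(NC(=O)c2cccc(/C=C3\CC(=O)N(c4ccccc4)C3=O)c2)c1` gives > 100000 nM in an ADME assay on NCM460 cells (Homo sapiens) for cytotoxicity, read by MTT assay, with a stated time of 72 h; on this read-out lower numbers stand for stronger inhibition and higher numbers for weaker inhibition.
Compound 2 `CCCCCN1C(=O)C/C(=C\c2cccc(C(=O)Nc3cccc(CC)c3)c2)C1=O` gives > 100000 nM in this assay.
Compound 3 `CCOc1ccc(NC(=O)c2cccc(/C=C3\CC(=O)N(Cc4ccccc4)C3=O)c2)cc1` gives > 100000 nM in this assay.

Within the data shown here, each of these three values is a limit of this assay rather than a number, and every compound measured so far sits at the limit of > 100000 nM in this assay, at which 3 of the 3 values shown sit. Among the measured compounds shown here, compound 1 therefore stands nowhere distinct: its result is a limit, and no step between measured compounds can be read off, so no size or direction of change has been seen in this assay.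

Compound 4 `COc1ccc(OC)c(NC(=O)c2cccc(/C=C3\CC(=O)N(c4ccccc4)C3=O)c2)c1` is the one still to be measured. It differs from compound 1 by 2,5-dimethoxyphenyl in place of 3-methylphenyl on an amide-type nitrogen, the same difference cut one bond further out reading (3-methylphenyl)amino to (2,5-dimethoxyphenyl)amino.

Since all three measured compounds sit at a limit, the step from compound 1 to compound 4 is expected to be none beyond the scatter in this assay, a number no higher from compound 1 to compound 4 (the limit leaves the size open). Compound 4 is accordingly expected to give about 100000 nM, with a plausible range from 30000 nM to 300000 nM, and most likely to be reported again as a limit.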

Compound 4, half-maximal inhibitory concentration: > 100000 nM
Compound 4: a limit, no number; the forecaster's own chance of this, stated with the estimate: 85%; the middle value lies on the limit itself.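

Among these compounds, the result for compound 4 is a limit, as is that for compound 1, so no step between them can be read in this assay: the limit of > 100000 nM in this assay, at which 4 of the 4 values shown sit.

The compounds shown leave open whether compound 1, compound 2, compound 3 and compound 4 differ at all in this assay, and whether any change would give a number rather than a limit.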